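Moving the benzothiazole attachment point in a weak compound

This account rests on a few compounds, and the source may have more. Where it says the series, first, only, none or still open, it means among the compounds named here.

In a functional assay on MCF7 cells (Homo sapiens) for antiproliferative activity, read by CellTiter-Glo, with a stated time of 5 days (a lower number here means a stronger inhibitor, a higher number a weaker inhibitor), compound 1 (`CC/C(=C(/c1ccc(/C=C/C(=O)O)cc1)c1ccc2[nH]ncc2c1)c1ccccc1`), which carries 1H-indazol-5-yl, gives 7.2 nM. Compound 2 (`CC/C(=C(/c1ccc(/C=C/C(=O)O)cc1)c1ccn2nncc2c1)c1ccccc1`) reads > 500 nM, and this is a limit of the assay, not a number. Compound 3 (`CC/C(=C(/c1ccc(/C=C/C(=O)O)cc1)c1ccc2ncsc2c1)c1ccccc1`), which carries 1,3-benzothiazol-6-yl, reads > 500 nM, which is likewise only a limit. Compound 3 therefore has no number of its own, and the record shows (the limit of > 500 nM in this assay, at which 2 of the 3 values shown sit). Two large steps lead to this limit: an at least 69-fold higher number from compound 1 to compound 2 (1.84 log units; beyond the scatter), and an at least 69-fold higher number from compound 1 to compound 3 (1.84 log units; beyond the scatter). Between the two limited compounds there is only a step that the two limits leave unreadable from compound 2 to compound 3.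

Compound 4 (`CC/C(=C(/c1ccc(/C=C/C(=O)O)cc1)c1ccc2scnc2c1)c1ccccc1`) has the same atoms as compound 3, joined differently: 1,3-benzothiazol-5-yl in place of 1,3-benzothiazol-6-yl on a double-bonded chain carbon bound to an aromatic carbon and a double-bonded chain carbon. Among the measured compounds shown here, no measured step tests this change directly. The closest guide is the large loss seen with compound 3, an at least 69-fold higher number from compound 1 to compound 3 (1.84 log units; beyond the scatter), since compound 4 also carries a benzothiazole group rather than 1H-indazol-5-yl. Compound 4 is therefore expected to remain weak in this assay, and no clear gain is expected. The expected change is a step that the limit leaves unreadable from compound 3 to compound 4. The estimate for compound 4 is 600 nM, with an expected range from 150 nM to 2500 nM.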

Compound 4, half-maximal inhibitory concentration: 90 nM
For compound 4 the middle estimate is 6.7-fold (0.82 log units) above the measured one, outside the stated range (below it).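

In this assay, the change to 1,3-benzothiazol-5-yl from 1,3-benzothiazol-6-yl, with the same atoms joined differently, gives an at least 5.5-fold lower number from compound 3 to compound 4 (0.74 log units; beyond the scatter), so at this place the point of attachment matters and not only the atoms of the group. A benzothiazole group is therefore not weak in every form, yet the 5-yl group does not reach the level of 1H-indazol-5-yl: the record shows a 13-fold higher number from compound 1 to compound 4 (1.10 log units; beyond the scatter), while the comparison with the other limited compound shows an at least 5.5-fold lower number from compound 2 to compound 4 (0.74 log units; beyond the scatter). The two lower-number steps start from limits and not from numbers, so their true sizes stay unknown: the limit of > 500 nM in this assay, at which 2 of the 4 values shown sit.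

The compounds shown leave open which feature of 1H-indazol-5-yl accounts for the remaining difference, and how 1,3-benzoxazol-5-yl or 1H-benzimidazol-5-yl, with oxygen or an added ring nitrogen in place of sulfur, would read at the same place. They also leave open whether the preference for the 5-yl attachment would hold if the carboxylic acid on the shared core were replaced by an amide.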